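A few compounds are considered here, and "the series" means these few. Any claim that something is new, unique, unknown or untested is made for them only; others in the source may bear on it.

Measured in a functional assay on the whole organism (strain Wistar) for inhibition, with Rattus norvegicus as the target, read by paw edema, with a stated time of 2 h, at a dose of 100 mg/kg; a higher number here means more inhibition at the dose given (going by the name of the read-out), a lower number less inhibition:
Compound 1 `COc1cc2c(cc1OC)C(CC(=O)O)CC2` gives 24%.
Compound 2 `COc1cc2c(cc1OC)C(CC(=O)Nc1ccc(Br)cc1)CC2` gives 40%.

Going by the values given here, compound 2 stands highest of the two numbers, with compound 1 as its only neighbour. Among the compounds with values here, the single step measured so far, a number 16 percentage points higher from compound 1 to compound 2 (beyond the scatter), is a modest rise beyond the scatter for (4-bromophenyl)amino in place of hydroxy on a carbonyl carbon. Compound 3 `COc1cc2c(cc1OC)C(CC(=O)Nc1cccc(C)c1)CC2` has not yet been measured in this assay. Its difference from compound 2 is 3-methylphenyl in place of 4-bromophenyl on an amide-type nitrogen. Within the data shown here, no measured step bears directly on this change: the step already seen concerns the arrival of the (4-bromophenyl)amino group itself, not the exchange of one aryl group for another of the same size on the amide-type nitrogen. The data therefore give no direction for the new compound, and a step of no more than the scatter, in either direction, is the plain expectation. Compound 3 is accordingly estimated at 36%, within a range from 20% to 52%. The step this estimate implies, a number 4 percentage points lower from compound 2 to compound 3 (within the scatter), is expected to stay within the scatter.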

Compound 3, a percentage reported as inhibition, in the whole organism at one dose (the size of the read-out at that dose, not a potency): 29%
Compound 3: the middle estimate sits 7 percentage points above what was measured; the measured number falls inside the stated range.
By their numbers in this assay, from the lowest: compounds 1 and 3 (each within the scatter of the next); then compound 2.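

In this assay, the aryl group on the amide-type nitrogen proves not to be freely exchangeable: 3-methylphenyl in place of 4-bromophenyl, two groups of 7 heavy atoms that each hold one six-membered aromatic ring of carbon only, gives a number 11 percentage points lower from compound 2 to compound 3 (beyond the scatter) and so a modest loss at this position. The amide alone therefore does not account for the rise seen with compound 2, since (3-methylphenyl)amino in place of hydroxy on a carbonyl carbon gives a number 5 percentage points higher from compound 1 to compound 3 (within the scatter) and leaves compound 3 no clear gain over compound 1. Nothing measured here accounts for the difference between the two aryl groups.

The change from compound 2 to compound 3 alters both the substituent and its place on the ring, so the compounds shown cannot separate the loss of bromine from the arrival of methyl or from the move between the two ring positions. On these data alone, that question would need groups such as 3-bromophenyl, 4-methylphenyl or plain phenyl on the same amide-type nitrogen, and how a non-aromatic group such as cyclohexyl would behave there also remains open.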